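The source may report more compounds than this note shows. Statements on the series, on what has been measured and on what is new or still open speak of the compounds shown alone.

Measured compounds so far:
Compound 1, `N#Cc1ccccc1CN1CCc2c(sc(NC(=O)c3ccccc3Cl)c2C(N)=O)C1`: in a functional assay on HeLa cells (Homo sapiens) for antiproliferative activity, with a stated time of 24 h (on this read-out higher numbers stand for weaker inhibition and lower numbers for stronger inhibition), compound 1 gives > 50000 nM, a limit of the assay rather than a number.
Compound 2, `NC(=O)c1c(NC(=O)c2ccc(C(F)(F)F)cc2)sc2c1CCN(Cc1c(Cl)cccc1Cl)C2`: in this assay compound 2 gives > 50000 nM, again a limit.
Compound 3, `NC(=O)c1c(NC(=O)c2ccccc2Cl)sc2c1CCN(C(=O)Nc1ccccc1Cl)C2`: in this assay compound 3 gives 45400 nM.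

Compound 1 therefore stands at the limit, with no number of its own. Going by the values given here, the only numbered value among the three belongs to compound 3, and the step of an at least 1.1-fold lower number from compound 1 to compound 3 (0.04 log units; that floor lies within the scatter) lies within the scatter. Two of the three values sit at the limit of > 50000 nM in this assay, at which 2 of the 3 values shown sit, so the series as shown is essentially inactive in this assay.

Compound 4, `CSc1ccccc1NC(=S)N1CCc2c(sc(NC(=O)c3ccccc3Cl)c2C(N)=O)C1`, differs from compound 1 at the ring nitrogen: a group of 11 heavy atoms (8 carbon, 1 nitrogen, 2 sulfur; one six-membered aromatic ring of carbon only) in place of a group of 9 heavy atoms (8 carbon, 1 nitrogen; one six-membered aromatic ring of carbon only), on an amine nitrogen in a ring. Among the compounds with values here, no measured step bears directly on this change; the one measured step, an at least 1.1-fold lower number from compound 1 to compound 3 (0.04 log units; that floor lies within the scatter), replaced the same 2-cyanobenzyl with a (2-chlorophenyl)carbamoyl group and left the number near the limit. For compound 4 no step beyond the scatter is expected in this assay, in either direction; the expected step is a number no higher from compound 1 to compound 4 (the limit leaves the size open). Compound 4 is estimated at 50000 nM, within 20000 nM to 150000 nM, most likely reported again as a limit.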

Compound 4, half-maximal inhibitory concentration: 43600 nM
For compound 4 the middle estimate is 1.1-fold (0.06 log units) above the measured one, within the range that was stated.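

In this assay, the step is a 1.0-fold lower number from compound 3 to compound 4 (0.02 log units; within the scatter), so a urea-type (2-chlorophenyl)carbamoyl group and the sulfur-bearing group of compound 4 cannot be told apart on the amine nitrogen in the ring. Leaving the 2-cyanobenzyl group gives an at least 1.1-fold lower number from compound 1 to compound 4 (0.05 log units; that floor lies within the scatter), and the true size of that step stays unknown, as the value of compound 1 is a limit. The new number adds a second measured compound to the series, yet no change at this position has moved the read-out beyond the scatter, and some of the values remain a limit: the limit of > 50000 nM in this assay, at which 2 of the 4 values shown sit.

Going by these compounds, whether a carboxylic acid, an amine or a longer chain on this ring nitrogen would give a step beyond the scatter remains open. Changes to the shared core itself also remain open.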